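This account rests on a few compounds, and the source may have more. Where it says the series, first, only, none or still open, it means among the compounds named here.

Series notes, topoisomerase set.

Compound 1 `Cc1ccc(-c2cc(-c3ccoc3)cc(-c3ccc(Cl)s3)n2)cc1` is the reference. In an assay on isolated protein for inhibition of DNA topoisomerase 1 (Homo sapiens), with a stated time of 30 min, tested at 100 uM (a higher number here means more inhibition at the concentration tested (going by the name of the read-out), a lower number less inhibition), compound 1 gives 0%. Compound 2 `Clc1ccc(-c2cc(-c3ccoc3)cc(-c3ccccc3Cl)n2)s1` differs from it only at one aromatic carbon of the shared core, and in this assay compound 2 gives 0%. The step of no change at the digits printed from compound 1 to compound 2 (within the scatter) is the only one so far, so compound 2 stands level with compound 1 at the digits shown, with no other measured neighbour to compare against.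

Compound 3 `Clc1cccc(-c2cc(-c3ccoc3)cc(-c3ccc(Cl)s3)n2)c1` is the next variation at the same place. The change is 3-chlorophenyl in place of 2-chlorophenyl on an aromatic carbon. Going by the values given here, the single measured step bears on it in kind, as another rearrangement of the group on this carbon, and that step did not move the read-out beyond the scatter. The expected step of no change at the digits printed from compound 2 to compound 3 (within the scatter) is therefore none beyond the scatter. For compound 3 the estimate in this assay is 0%, with a range from -5% to 10%.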

Compound 3, a percentage reported as inhibition, at one concentration (the size of the read-out at that concentration, not a potency): 2.1%
Compound 3: the middle estimate sits 2.1 percentage points below what was measured; the measured number falls inside the stated range.
By their numbers in this assay, from the lowest: compounds 1, 2 and 3 (each within the scatter of the next).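

In this assay the exchange of 2-chlorophenyl for 3-chlorophenyl gives a number 2.1 percentage points higher from compound 2 to compound 3 (within the scatter) and the exchange of 4-methylphenyl for 3-chlorophenyl gives a number 2.1 percentage points higher from compound 1 to compound 3 (within the scatter) so all three groups on this carbon, next to the ring nitrogen, now read alike. The earlier pair changed the substituent itself, whereas compounds 2 and 3 hold the same atoms joined differently, which shows that relocating the chlorine on the phenyl ring also leaves the read-out within the scatter. No measured evidence on the compounds accounts for this flat result.

All three numbers lie close together, so the compounds shown do not tell whether any group on this carbon can raise the inhibition. On these data alone, a group of another kind here, such as a piperazine, an aminomethyl group or a carboxylic acid, remains open, as do replacements for the furan-3-yl and 5-chlorothiophen-2-yl groups.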